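A few compounds are considered here, and "the series" means these few. Any claim that something is new, unique, unknown or untested is made for them only; others in the source may bear on it.

Working notes on the series. Three compounds sharing one core have numbers in an assay on LtK cells with ATP-sensitive inward rectifier potassium channel 11 (Homo sapiens) as the target; on this read-out lower numbers stand for an effect already at smaller amounts and higher numbers for an effect only at larger amounts of compound. Compound 1 `O=C(Nc1ccc(Cl)cc1)Nc1c(C(O)(C(F)(F)F)C(F)(F)F)ccc2ccccc12` gives 276 nM. Compound 2 `O=C(Nc1c(C(O)(C(F)(F)F)C(F)(F)F)ccc2ccccc12)c1ccccc1` gives 44 nM. Compound 3 `COc1cccc(C(=O)Nc2c(C(O)(C(F)(F)F)C(F)(F)F)ccc3ccccc23)c1` gives 185 nM, the second highest of the three; its nearest neighbour is compound 1, within the scatter, and its furthest is compound 2, with a 4.2-fold higher number from compound 2 to compound 3 (0.62 log units; beyond the scatter) separating the two.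

Compound 4 `O=C(Nc1c(C(O)(C(F)(F)F)C(F)(F)F)ccc2ccccc12)c1cccnc1` is not yet measured. Relative to compound 3 the change is pyridin-3-yl in place of 3-methoxyphenyl on a carbonyl carbon. For the measured compounds named here, two measured steps bear on it. The step of a 4.2-fold higher number from compound 2 to compound 3 (0.62 log units; beyond the scatter) shows that methoxy in place of hydrogen on an aromatic carbon raised the number, so taking the 3-methoxyphenyl away again should recover part of that. Going by the values given here, the step of a 6.3-fold lower number from compound 1 to compound 2 (0.80 log units; beyond the scatter) shows that phenyl on the carbonyl carbon gave the lowest number so far; the swap of phenyl for pyridin-3-yl has no measured counterpart here, so its own contribution is unknown. The expectation for compound 4 is therefore a step of a 2.6-fold lower number from compound 3 to compound 4 (0.42 log units; beyond the scatter), downward, beyond the scatter. Compound 4 is estimated at 70 nM, with a range from 25 nM to 200 nM.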

Compound 4, half-maximal effective concentration: 60 nM
For compound 4 the middle estimate is 1.2-fold (0.07 log units) above the measured one, within the range that was stated.
By their numbers in this assay, from the lowest: compounds 2 and 4 (each within the scatter of the next); then compounds 3 and 1 (each within the scatter of the next).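

In this assay the carbonyl carbon accepts pyridin-3-yl, a ring with one hetero atom, in place of the all-carbon phenyl without a step that can be read: a 1.4-fold higher number from compound 2 to compound 4 (0.13 log units; within the scatter) stays within the scatter, so compound 2 and compound 4 cannot be placed in an order. Compound 4 is clearly separated from the two higher compounds, with a 3.1-fold lower number from compound 3 to compound 4 (0.49 log units; beyond the scatter) against the 3-methoxyphenyl group and a 4.6-fold lower number from compound 1 to compound 4 (0.66 log units; beyond the scatter) against the (4-chlorophenyl)amino group. Nothing available accounts for these steps. Going by these compounds, what remains open is how far the tolerance of this position extends, for example to a pyridin-3-yl ring carrying a methoxy, an amine or a carboxylic acid. On these data alone, whether a longer chain between the carbonyl carbon and the ring is accepted is equally open.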